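The source may hold more compounds than are shown below. What is called first, only, known or untested is meant among the compounds shown, and "the series" means these compounds.

Working notes on the furan amidine series. The shared core appears in compound 1 `CC(C)(C)c1ccc(-c2ccc(-c3ccc(C(=N)N)cc3)o2)cc1`, compound 2 `Cc1ccc(-c2ccc(-c3ccc(C(=N)N)cc3)o2)cc1` and compound 3 `N=C(N)c1ccc(-c2ccc(-c3ccc([N+](=O)[O-])cc3)o2)cc1`. In an assay on isolated protein for inhibition of ribosyldihydronicotinamide dehydrogenase [quinone] (Homo sapiens), read by spectrophotometry, with a stated time of 1 min (on this read-out lower numbers stand for stronger inhibition and higher numbers for weaker inhibition), compound 1 gives 712 nM, compound 2 gives 110 nM and compound 3 gives 24 nM; compound 2 thus stands second highest of the three, with compound 3 nearest and compound 1 furthest. The measured steps are a 6.5-fold lower number from compound 1 to compound 2 (0.81 log units; beyond the scatter), a 30-fold lower number from compound 1 to compound 3 (1.47 log units; beyond the scatter) and a 4.6-fold lower number from compound 2 to compound 3 (0.66 log units; beyond the scatter), each a swap of the group carried on an aromatic carbon of the 4-methylphenyl end.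

Compound 4 `N=C(N)c1ccc(-c2ccc(-c3cccc(F)c3)o2)cc1` departs from compound 2 differently: 3-fluorophenyl in place of 4-methylphenyl on an aromatic carbon. Among the measured compounds shown here, no measured step exchanges a whole ring or brings in fluorine, so the three steps bear only loosely on this change; they show that exchanges at this end of the molecule can move this assay by modest to large amounts, with compound 2 between the two extremes. Without a closer precedent, the step is expected to be small, and compound 4 is expected at 150 nM in this assay, within 55 nM to 420 nM, an expected step of a 1.4-fold higher number from compound 2 to compound 4 (0.13 log units; within the scatter).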

Compound 4, half-maximal inhibitory concentration: 111 nM
The estimate for compound 4 lay 1.4-fold (0.13 log units) above the measured number; the measured number falls inside the stated range.
By their numbers in this assay, from the lowest: compound 3; then compounds 2 and 4 (each within the scatter of the next); then compound 1.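

In this assay, 3-fluorophenyl in place of 4-methylphenyl on the aromatic carbon next to the ring oxygen gives a 1.0-fold higher number from compound 2 to compound 4 (0.00 log units; within the scatter), so compounds 2 and 4 cannot be told apart. Among the compounds shown here, every earlier step at this end of the molecule lay beyond the scatter, so this pair is the first to show that an exchange here can leave the read-out unresolved, even with the ring's substituent and its location both differing. No measured property bears on this result, and the data offer no explanation for it.

Because two features differ at once, the pair cannot separate the contribution of fluorine from that of its location on the ring. Direct comparisons with 3-methylphenyl, 4-fluorophenyl or unsubstituted phenyl would address this, and how an amine or a carboxylic acid on this ring would read remains open.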